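Swapping the aryl group on the shared core: furan to thiophene

This account rests on a few compounds, and the source may have more. Where it says the series, first, only, none or still open, it means among the compounds named here.

Compound 1 `COc1ccccc1C1C(C#N)=C(N)N(c2ccc(S(N)(=O)=O)cc2)C2=C1CCCC2`: 40%
Compound 2 `Cc1ccc(C2C(C#N)=C(N)N(c3ccc(S(N)(=O)=O)cc3)C3=C2CCCC3)o1`: 10%

Within the data shown here, in a functional assay on Ehrlich cells (Mus musculus) for cytotoxicity, read by trypan blue exclusion, with a stated time of 2 h, tested at 25 ug/mL (on this read-out lower numbers stand for a weaker effect and higher numbers for a stronger effect at the one concentration tested), compound 2 gives 10%, the lowest of the two numbers known; the only other number, that of compound 1, is higher by a number 30 percentage points lower from compound 1 to compound 2 (beyond the scatter). Compound 3 `N#CC1=C(N)N(c2ccc(S(N)(=O)=O)cc2)C2=C(CCCC2)C1c1cccs1` differs from compound 2 by one change: thiophen-2-yl in place of 5-methylfuran-2-yl on a saturated ring carbon. Among the measured compounds shown here, no measured step bears on this exact change, since the single step from compound 1 to compound 2 concerns a different swap of the aryl group. With nothing pointing either way, the number for compound 3 is expected to stay close to that of compound 2, a step of a number 5 percentage points higher from compound 2 to compound 3 (within the scatter) not beyond the scatter. Compound 3 is therefore estimated at 15%, between 5% and 35%.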

Compound 3, a percentage reported as activity, at one concentration (the size of the read-out at that concentration, not a potency): 5%
For compound 3 the middle estimate is 10 percentage points above the measured one; the measured number falls inside the stated range.
By their numbers in this assay, from the lowest: compounds 3 and 2 (each within the scatter of the next); then compound 1.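

In this assay the swap of 5-methylfuran-2-yl for thiophen-2-yl on this saturated ring carbon gives a step of a number 5 percentage points lower from compound 2 to compound 3 (within the scatter) and so does not separate these two five-membered aromatic rings. The wider swap from 2-methoxyphenyl gives a number 35 percentage points lower from compound 1 to compound 3 (beyond the scatter) and shows that a second five-membered ring also reads well under the 2-methoxyphenyl compound. No measurement offers an explanation for either step.

Still open, as far as these compounds go, is whether plain phenyl, without the methoxy group, would read like compound 1 or like compound 3. From the compounds shown here alone, a phenyl ring carrying an amine or a carboxylic acid at this carbon is equally open.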